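Ethyl in place of benzyl on the ring nitrogen

This account rests on a few compounds, and the source may have more. Where it says the series, first, only, none or still open, it means among the compounds named here.

Measured compounds in a functional assay on HeLa cells (Homo sapiens) for cytotoxicity, read by cell counting, with a stated time of 4 days; a lower number here means a stronger inhibitor, a higher number a weaker inhibitor:
- compound 1, `CC(C)(C)c1ccc(CN2C(=O)S/C(=C\c3ccc(N)cc3)C2=O)cc1`, gives 53000 nM
- compound 2, `Nc1ccc(/C=C2\SC(=O)N(Cc3ccccc3)C2=O)cc1`, gives 46000 nM
- compound 3, `C=C(Br)C(=O)Nc1ccc(/C=C2\SC(=O)N(Cc3ccccc3)C2=O)cc1`, gives 1000 nM

Compound 2 holds the second highest of the three numbers. Its nearest neighbour is compound 1, a 1.2-fold lower number from compound 1 to compound 2 (0.06 log units; within the scatter), so the two cannot be told apart. Among the compounds with values here, the only well-separated pair is a 46-fold lower number from compound 2 to compound 3 (1.66 log units; beyond the scatter), which sits at the aromatic amine and not on the benzyl side.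

Compound 4, `CCN1C(=O)S/C(=C\c2ccc(N)cc2)C1=O`, is not yet measured. It differs from compound 2 as follows: methyl in place of phenyl on a saturated chain carbon bound to an amide-type nitrogen in a ring.

Within the data shown here, of the two measured steps, only the one from compound 1 to compound 2 concerns the group on the ring nitrogen, and it stayed within the scatter. The step to compound 3 lies elsewhere and says nothing about this position. There is thus one indication that this part of the molecule is tolerant to change, but the removal of the whole phenyl is a larger cut than was tested. The expectation is therefore no step beyond the scatter, with a lean toward a somewhat higher number; the estimated step is a 1.3-fold higher number from compound 2 to compound 4 (0.12 log units; within the scatter).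

For compound 4 the estimate in this assay is 60000 nM, with a range of 25000 nM to 150000 nM.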

Compound 4, half-maximal inhibitory concentration: 108000 nM
The estimate for compound 4 lay 1.8-fold (0.26 log units) below the measured number; measured number inside the range.
By their numbers in this assay, from the lowest: compound 3; then compounds 2 and 1 (each within the scatter of the next); then compound 4.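

Cutting benzyl to ethyl on the amide-type nitrogen in a ring gives, in this assay, a 2.3-fold higher number from compound 2 to compound 4 (0.37 log units; beyond the scatter), the first step at this position that lies beyond the scatter. The earlier change here, a 1.2-fold lower number from compound 1 to compound 2 (0.06 log units; within the scatter), removed only the tert-butyl from the aromatic ring and stayed within the scatter, so tolerance of that substituent does not extend to replacing the whole phenyl with methyl, although the step is modest. No measurement shown here accounts for this step.

Open, from the compounds shown here alone, is whether the step follows the loss of the aromatic ring or the shorter chain: a cyclohexylmethyl group or an n-butyl chain on the same nitrogen would help separate the two. Also open, going by these compounds, is whether the benzyl to ethyl change has a similar effect when the aromatic amine carries the (1-bromoethenyl)carbonyl group, as in compound 3 at 1000 nM, or whether an aminoethyl or carboxymethyl group on that nitrogen would give a different number in this assay.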